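From Acid to Amide on a Shared Aldehyde Core

The compounds below may be only part of what the source reports. "The series", "measured", "known", "first", "only" and "open" are said of these compounds alone.

Compound 2 `O=Cc1cc(-c2ccccc2)c2ccc(C(=O)O)ccc1-2` gives 16.2% in an assay on cells for displacement of a labelled ligand from Orexin/Hypocretin receptor type 1 (Homo sapiens), read by scintillation counting, with stated times of 10 min and 90 min, tested at 10 uM (on this read-out higher numbers stand for more inhibition at the one concentration tested (going by the name of the read-out) and lower numbers for less inhibition), and so stands highest of the two numbers measured, though the nearest number, that of compound 1 `COC(=O)c1ccc2c(C=O)cc(-c3ccccc3)c-2cc1` at 8.5%, lies within the scatter of it. Among the compounds with values here, the one measured step, a number 7.7 percentage points higher from compound 1 to compound 2 (within the scatter), exchanges a methyl for hydrogen on the oxygen of the carbonyl group and changes the read-out by an amount that repeated measurements could produce on their own.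

Compound 3 `NC(=O)c1ccc2c(C=O)cc(-c3ccccc3)c-2cc1` differs from compound 2 by amino in place of hydroxy on a carbonyl carbon. Within the data shown here, the only step in hand touches the same carbonyl group and stayed within the scatter, so there is no measured ground for expecting a shift beyond the scatter in this assay. Compound 3 is therefore expected to give about 12%, between 0% and 30%, an estimated step of a number 4.2 percentage points lower from compound 2 to compound 3 (within the scatter).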

Compound 3, a percentage reported as inhibition, at one concentration (the size of the read-out at that concentration, not a potency): 6.1%
Estimate against measurement, compound 3: 5.9 percentage points above; the range from low to high includes it.
By their numbers in this assay, from the lowest: compounds 3, 1 and 2 (each within the scatter of the next, the first and the last beyond it).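

Swapping carboxy for carbamoyl on the carbonyl carbon gives a number 10.1 percentage points lower from compound 2 to compound 3 (beyond the scatter) in this assay, the only step among these compounds that lies beyond the scatter, so a change at this position can register in the read-out, if modestly. Amino in place of methoxy on the same carbon gives a number 2.4 percentage points lower from compound 1 to compound 3 (within the scatter), so the methyl ester and the carbamoyl compound cannot be told apart here, and only the exchange starting from the carboxy group stands out from the scatter. Nothing available explains this difference between the steps.

From the compounds shown here alone, whether a methyl group or a longer chain on the nitrogen of the carbamoyl group would move the number stays open. So does whether a hydroxymethyl group in place of the aldehyde on the shared core would change the read-out at all.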